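Ring size at the urea terminus of a quinoline series

This account rests on a few compounds, and the source may have more. Where it says the series, first, only, none or still open, it means among the compounds named here.

Compounds measured so far:
compound 1, `CCN(CC)C(=O)NCCCC(C)Nc1cc(OC)cc2cccnc12`: 58000 nM
compound 2, `COc1cc(NC(C)CCCNC(=O)NCc2ccncc2)c2ncccc2c1`: 18000 nM
compound 3, `COc1cc(NC(C)CCCNC(=O)NC2CCCC2)c2ncccc2c1`: 21000 nM

The three compounds share one core and differ only in the group on the carbonyl of the urea. In a functional assay on HeLa cells (Homo sapiens), read by MTT assay, with a stated time of 72 h (a higher number here means a weaker inhibitor, a lower number a stronger inhibitor), compound 1 gives 58000 nM, the highest number of the three. Compound 2 gives 18000 nM and compound 3 gives 21000 nM. Compound 3 stands second highest; its gap to compound 2 is within the scatter, while its gap to compound 1 is beyond it: a 2.8-fold lower number from compound 1 to compound 3 (0.44 log units; beyond the scatter), and in the same sense a 3.2-fold lower number from compound 1 to compound 2 (0.51 log units; beyond the scatter). Between the two ring-bearing analogues the step is small: a 1.2-fold higher number from compound 2 to compound 3 (0.07 log units; within the scatter).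

Compound 4, `COc1cc(NC(C)CCCNC(=O)NC2CCCCC2)c2ncccc2c1`, is not yet measured. It differs from compound 3 in one place: cyclohexyl in place of cyclopentyl on an amide-type nitrogen. For the measured compounds named here, no measured step changes the size of a saturated ring; the nearest comparison, the exchange of cyclopentyl for (pyridin-4-yl)methyl, stayed within the scatter. A step of no more than the scatter is therefore expected in this assay, with no clear direction. Compound 4 is estimated at 18000 nM, with a range from 8000 nM to 40000 nM, which is expected to mean a step of a 1.2-fold lower number from compound 3 to compound 4 (0.07 log units; within the scatter).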

Compound 4, half-maximal inhibitory concentration: > 100000 nM
Compound 4: no number, only a limit; the forecaster's own chance of this, stated with the estimate: 5%; middle value at least 5.5-fold (0.74 log units) from the limit.
By their numbers in this assay, from the lowest: compounds 2 and 3 (each within the scatter of the next); then compound 1. At a limit, above all of these: compound 4.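

In this assay compound 4 carries no number, only a limit: the limit of > 100000 nM in this assay, at which 1 of the 4 values shown sits.

Going from a five-membered to a six-membered non-aromatic ring on the amide-type nitrogen gives an at least 4.7-fold higher number from compound 3 to compound 4 (0.67 log units; beyond the scatter), and putting cyclohexyl in place of (pyridin-4-yl)methyl there gives an at least 5.5-fold higher number from compound 2 to compound 4 (0.74 log units; beyond the scatter), so this position, where compound 2 and compound 3 had stayed within the scatter of each other, does respond to the size of a saturated ring. Against the diethylamino group the reading is an at least 1.7-fold higher number from compound 1 to compound 4 (0.23 log units; that floor lies within the scatter), so compound 4 does not share the lower numbers that compound 2 and compound 3 showed relative to compound 1, yet it cannot be set clearly apart from compound 1.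

From the compounds shown here alone, the true number of compound 4 stays open, so its steps are known only as floors. Going by these compounds, whether cyclobutyl, cycloheptyl or a piperidine ring on this nitrogen would sit with compound 3 or with compound 4 also remains open, and with it whether the five-membered ring marks a limit of size or a narrow optimum.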